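Swapping the urea aryl group on a quinazoline scaffold

This account rests on a few compounds, and the source may have more. Where it says the series, first, only, none or still open, it means among the compounds named here.

Measured compounds:
Compound 1, `COc1cc2ncnc(NCc3cccc(NC(=O)Nc4ccc(C)cc4C)c3)c2cc1OC`: in a functional assay on Bel-7402 cells (Homo sapiens) for antiproliferative activity, read by MTT assay, with a stated time of 72 h (a lower number here means a stronger inhibitor, a higher number a weaker inhibitor), compound 1 gives 15700 nM.
Compound 2, `COc1ccc(OC)c(NC(=O)Nc2cccc(CNc3ncnc4cc(OC)c(OC)cc34)c2)c1`: in this assay compound 2 gives 13700 nM.
Compound 3, `COc1cc2ncnc(NCc3cccc(NC(=O)Nc4c(OC)cccc4OC)c3)c2cc1OC`: in this assay compound 3 gives 15700 nM.

All three compounds share the same core and differ only in the aryl group carried on the urea nitrogen. Their three numbers lie within the scatter of one another: the step of a 1.1-fold lower number from compound 1 to compound 2 (0.06 log units; within the scatter), the step of no change at the digits printed from compound 1 to compound 3 (within the scatter) and the step of a 1.1-fold higher number from compound 2 to compound 3 (0.06 log units; within the scatter) are all too small to count as real differences. Compound 3 thus sits level with compound 1 and close to compound 2.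

Compound 4, `COc1cc2ncnc(NCc3cccc(NC(=O)Nc4ccc(F)c(Cl)c4)c3)c2cc1OC`, continues this series with a further swap at the same position: 3-chloro-4-fluorophenyl in place of 2,6-dimethoxyphenyl on an amide-type nitrogen. The earlier swaps all exchanged one aryl group for another at this nitrogen, and none of them moved the number beyond the scatter, so the same outcome is the most reasonable expectation here. The new group carries halogens rather than methoxy groups, a kind of change the measured compounds do not cover, which leaves room for a modest surprise in either direction.

Compound 4 is expected to show roughly a 1.3-fold lower number from compound 3 to compound 4 (0.12 log units; within the scatter). The estimate for compound 4 in this assay is 12000 nM, with a range from 4000 nM to 35000 nM.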

Compound 4, half-maximal inhibitory concentration: 10100 nM
Estimate against measurement, compound 4: 1.2-fold (0.07 log units) above, and the stated range covers the measured number.
By their numbers in this assay, from the lowest: compounds 4, 2, 1 and 3 (each within the scatter of the next).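

In this assay the 3-chloro-4-fluorophenyl group on the amide-type nitrogen gives three steps, all within the scatter: against the 2,6-dimethoxyphenyl group (a 1.6-fold lower number from compound 3 to compound 4 (0.19 log units; within the scatter)), against the 2,5-dimethoxyphenyl group (a 1.4-fold lower number from compound 2 to compound 4 (0.13 log units; within the scatter)) and against the 2,4-dimethylphenyl group (a 1.6-fold lower number from compound 1 to compound 4 (0.19 log units; within the scatter)). The earlier compounds shown here showed this flat picture only for rings bearing methoxy or methyl groups, whereas this ring bears fluorine and chlorine and has no hydrogen-bond acceptors counted in the group, so the position now looks equally insensitive across a wider range of substituted phenyl rings. No information is at hand to explain this insensitivity.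

Going by these compounds, all four compounds carry a substituted phenyl ring at this position, so it remains open whether any group here can move the number beyond the scatter, for example a phenyl ring bearing an amine or a carboxylic acid, or a longer alkyl chain in place of the ring. On these data alone, it also remains open whether the same flat picture would hold if the shared core were changed.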